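The compounds below may be only part of what the source reports. "The series", "measured", "known", "first", "only" and "open" are said of these compounds alone.

Compound 1 `O=c1ccn([C@@H]2O[C@H](COP(=O)(O)OP(=O)(O)O)[C@@H](O)[C@H]2O)c(=S)[nH]1`: 60 nM
Compound 2 `O=c1ccn([C@]23CC2[C@H](COP(=O)(O)OP(=O)(O)O)[C@@H](O)C3)c(=O)[nH]1`: 230 nM
Compound 3 `CSc1ccn([C@@H]2O[C@H](COP(=O)(O)OP(=O)(O)O)[C@@H](O)[C@H]2O)c(=O)n1`: 2300 nM

These three compounds were tested in an in vitro functional assay on 1321-N1 cells for agonist activity at P2Y purinoceptor 6 (Homo sapiens); a lower number here means that less compound is needed, a higher number that more compound is needed for the effect. Compound 3 gives the highest of the three numbers, beyond the scatter from both compound 2 and compound 1, so it needs the most material of the three to produce the effect. Compound 4 `NC(=O)CSc1ccn([C@@H]2O[C@H](COP(=O)(O)OP(=O)(O)O)[C@@H](O)[C@H]2O)c(=O)n1` has not yet been measured. It differs from compound 3 in one place: carbamoyl in place of hydrogen on a saturated chain carbon bound to a sulfur. Within the data shown here, no measured pair shows this particular change, so its effect can only be estimated. The expected step in this assay is small, a 1.2-fold lower number from compound 3 to compound 4 (0.06 log units; within the scatter), meaning no change beyond the scatter in either direction. Compound 4 is therefore expected to give about 2000 nM, with a range from 600 nM to 7000 nM.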

Compound 4, half-maximal effective concentration: 18000 nM
Compound 4: middle estimate off by 9.0-fold (0.95 log units), on the low side, outside the stated range (above it).
By their numbers in this assay, from the lowest: compound 1; then compound 2; then compound 3; then compound 4.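

In this assay, replacing a hydrogen on the saturated chain carbon bound to sulfur with carbamoyl gives a 7.8-fold higher number from compound 3 to compound 4 (0.89 log units; beyond the scatter). This position therefore does not accept every added group, and turning methylsulfanyl into (carbamoylmethyl)sulfanyl means more compound is needed for the effect. Nothing shown here explains this step.

On these data alone, it remains open whether the rise belongs to carbamoyl itself or would follow any group added on that carbon. A carboxylic acid or a plain methyl in the same place could help separate these two readings.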